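The source may hold more compounds than are shown below. What is called first, only, known or untested is meant among the compounds shown, and "the series" means these compounds.

Measured so far in an assay on cells for inhibition of HSP60/HSP10 (Homo sapiens), with a stated time of 60 min; a lower number here means a stronger inhibitor, a higher number a weaker inhibitor:

compound 1 `COc1ccc(Cl)cc1S(=O)(=O)Nc1ccc(-c2nc3ccccc3o2)cc1`: > 100000 nM.
compound 2 `O=S(=O)(Nc1ccc2oc(-c3ccccc3)nc2c1)c1ccccc1C(F)(F)F`: > 100000 nM.

For compound 2 the result > 100000 nM is a limit of this assay and not a number: the measurement stopped there without finding a value. For compound 1 the result > 100000 nM is likewise a limit. Among the compounds with values here, both readings therefore sit at the limit of > 100000 nM in this assay, at which 2 of the 2 values shown sit, so nothing in these data ranks one measured compound against the other, and no step between measured compounds can be drawn. Compound 1 stands simply at the weak end of this assay, with only a limit to its name.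

Compound 3 `O=S(=O)(Nc1ccc(-c2nc3ccccc3o2)cc1)c1ccc(F)cc1` has not yet been measured. It differs from compound 1 in one place: 4-fluorophenyl in place of 5-chloro-2-methoxyphenyl on a sulfonyl sulfur. Within the data shown here, with no measured step to lean on, the expectation rests on the two limits alone, and the step from compound 1 to compound 3 in this assay is expected to be none beyond the usual scatter, a number no higher from compound 1 to compound 3 (the limit leaves the size open). Compound 3 is accordingly estimated at 100000 nM, within a range from 30000 nM to 300000 nM, most likely again reported only as a limit.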

Compound 3, half-maximal inhibitory concentration: 73000 nM
Estimate against measurement, compound 3: 1.4-fold (0.14 log units) above, within the range that was stated.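

In this assay compound 3 is the first of the compounds shown to give an actual number, 73000 nM, so with 4-fluorophenyl on a sulfonyl sulfur the assay returns a value it can place. Compound 1 gives > 100000 nM, which is a limit of the assay and not a number. From the compounds shown here alone, putting 4-fluorophenyl in place of 5-chloro-2-methoxyphenyl therefore reads only as an at least 1.3-fold lower number from compound 1 to compound 3 (0.13 log units; that floor lies within the scatter), so the true size of this step stays unknown and the data cannot yet show that the change does anything beyond the scatter.

Still open, going by these compounds, is whether the chlorine or the methoxy of the group in compound 1 matters at all, and how an unsubstituted phenyl, a methyl, or a phenyl carrying an amine or a carboxylic acid would read on the same sulfonyl sulfur. Compound 2 differs from the other two compounds in more than one place, and the shown set gives few numbers to compare: the limit of > 100000 nM in this assay, at which 2 of the 3 values shown sit.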